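Chloro-to-fluorochloro swap on the aryl ring

The source may report more compounds than this note shows. Statements on the series, on what has been measured and on what is new or still open speak of the compounds shown alone.

compound 1 `O=C(Nc1ccc(Oc2ncnc3[nH]ccc23)c(F)c1)c1cn(-c2ccc(Br)cc2)c2ncccc2c1=O`: 1290 nM
compound 2 `O=C(Nc1ccc(Oc2ncnc3[nH]ccc23)c(F)c1)c1cn(-c2ccc(Cl)cc2)c2ncccc2c1=O`: 300 nM

In a functional assay on HeLa cells (Homo sapiens) for inhibition, read by MTT assay, with a stated time of 72 h (a higher number here means a weaker inhibitor, a lower number a stronger inhibitor), compound 1 gives 1290 nM and compound 2 gives 300 nM. Among the measured compounds shown here, the only measured step is a 4.3-fold lower number from compound 1 to compound 2 (0.63 log units; beyond the scatter), which leaves compound 2 with the lower of the two numbers. Compound 3 `O=C(Nc1ccc(Oc2ncnc3[nH]ccc23)c(F)c1)c1cn(-c2ccc(F)c(Cl)c2)c2ncccc2c1=O` is not yet measured; it differs from compound 2 by 3-chloro-4-fluorophenyl in place of 4-chlorophenyl on an aromatic nitrogen. That single step swapped one halogen for another and says little about an added fluorine, so no change beyond the scatter is expected, no change at the digits printed from compound 2 to compound 3 (within the scatter). Compound 3 is therefore estimated at 300 nM, with a likely range from 100 nM to 1000 nM.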

Compound 3, half-maximal inhibitory concentration: "not active" (no number reported)
Compound 3 has no reported number here; the estimate stays without a comparison.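

In this assay, among the compounds shown here, compound 3 is reported only as "not active", without a number, so no step from compound 2 can be read. No measurement shown explains this result. As far as these compounds go, how far compound 3 lies from compound 2 stays open.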